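The source may hold more compounds than are shown below. What is called first, only, known or untested is meant among the compounds shown, and "the series" means these compounds.

Measured compounds:
- compound 1, `CC(C)(C)C(=O)N1Cc2c(NC(=O)c3cccnc3)n[nH]c2C1(C)C`: 690 nM
- compound 2, `CN1CCC(C(=O)N2Cc3c(NC(=O)NCc4ccccc4)n[nH]c3C2(C)C)CC1`: 2680 nM
- compound 3, `CC(=O)N1CCC(C(=O)N2Cc3c(NC(=O)c4ccc(F)cc4)n[nH]c3C2(C)C)CC1`: a limit only, > 10000 nM

These three compounds share a core and differ in two places: the group on the left-hand amide nitrogen of the core and the group attached through a carbonyl to the amino group on the core. They were tested in a functional assay on A2780 cells (Homo sapiens) for antiproliferative activity, read by fluorescence, with a stated time of 72 h; on this read-out higher numbers stand for weaker inhibition and lower numbers for stronger inhibition. Compound 1 gives 690 nM. Compound 2 gives 2680 nM, the higher of the two numbers, and its gap from compound 1 lies beyond the usual scatter of this assay. For compound 3 this assay reports only a limit, > 10000 nM, and not a number.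

Compound 4, `CN1CCC(C(=O)N2Cc3c(NC(=O)c4ccc(C(F)(F)F)cc4)n[nH]c3C2(C)C)CC1`, has not yet been measured. It keeps the same left-hand group as compound 2 and differs from it in one place: 4-(trifluoromethyl)phenyl in place of benzylamino on a carbonyl carbon. Going by the values given here, no measured pair in this set isolates that change, so the size of the step cannot be read from the data. Compound 4 is expected to give about 2500 nM in this assay, within a range from 700 nM to 12000 nM. That estimate corresponds to an expected step of a 1.1-fold lower number from compound 2 to compound 4 (0.03 log units; within the scatter), which is not clearly beyond the scatter in either direction.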

Compound 4, half-maximal inhibitory concentration: 60 nM
Estimate against measurement, compound 4: 42-fold (1.62 log units) above, and the stated range ends above it.
By their numbers in this assay, from the lowest: compound 4; then compound 1; then compound 2. At a limit, above all of these: compound 3.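

Putting 4-(trifluoromethyl)phenyl in place of benzylamino on the carbonyl carbon, with the left-hand group unchanged, gives in this assay a 45-fold lower number from compound 2 to compound 4 (1.65 log units; beyond the scatter) and shows that this position strongly affects antiproliferative activity. The earlier compounds shown here could not show this, since each differs from the others in two places and no other step can be read. The change removes a nitrogen with its hydrogen-bond donor and the carbon chain link to the ring, and it brings in three fluorine atoms, but the data give no measured reason for the size of the step.

As far as these compounds go, it remains open whether the step comes from losing the benzylamino link or from gaining the trifluoromethyl group, and a plain phenyl or a 4-chlorophenyl on the same carbonyl carbon, with the left-hand group kept, would help separate the two. From the compounds shown here alone, it is also open how much the left-hand group contributes, and an acetyl group in place of the methyl on the left-hand piperidine-type ring of compound 4 would test that in a single change.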